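The source may report more compounds than this note shows. Statements on the series, on what has been measured and on what is new or still open speak of the compounds shown alone.

Measured in a functional assay on THP-1 cells (Homo sapiens) for inhibition, read by sulforhodamine B assay, with a stated time of 48 h; on this read-out higher numbers stand for weaker inhibition and lower numbers for stronger inhibition:
- Compound 1 `CCO[C@H]1C[C@@H](c2coc3ccc(F)cc3c2=O)N(c2ccccc2)O1`: > 60000 nM (a limit)
- Compound 2 `O=c1c([C@@H]2C[C@H](c3ccccc3)ON2c2ccccc2)coc2ccc(F)cc12`: 54700 nM

In this assay, for the measured compounds named here, compound 2 gives 54700 nM, the only actual number so far. The value of compound 1 is a limit, (the limit of > 60000 nM in this assay, at which 1 of the 2 values shown sits), so there is no number to rank compound 2 against.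

The next compound is compound 3 `O=c1c([C@@H]2C[C@H](c3ccccc3)ON2c2ccccc2)coc2ccc(Br)cc12`, which carries bromo in place of fluoro on an aromatic carbon of the shared core: bromo in place of fluoro on an aromatic carbon. Going by the values given here, the one measured step, an at least 1.0-fold lower number from compound 1 to compound 2 (0.04 log units; that floor lies within the scatter), is phenyl in place of ethoxy on a saturated ring carbon. Among the compounds with values here, that is a different change at a different place, so it bears only weakly on this swap, and no measured step covers a change of halogen. With so little to go on, a modest step towards a lower number in this assay is expected, and a step within the scatter would be no surprise. The estimated change is a 1.8-fold lower number from compound 2 to compound 3 (0.26 log units; within the scatter). Compound 3 is expected at 30000 nM, with an estimated range of 10000 nM to 65000 nM.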

Compound 3, half-maximal inhibitory concentration: 60000 nM
For compound 3 the middle estimate is 2.0-fold (0.30 log units) below the measured one, within the range that was stated.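

In this assay, bromo in place of fluoro on an aromatic carbon of the shared core gives a 1.1-fold higher number from compound 2 to compound 3 (0.04 log units; within the scatter), so the two halogens cannot be told apart at this position. Unlike the earlier step at the saturated ring carbon, which has only a floor, this step has an actual number at both ends and is therefore a measured difference. Compound 1 remains a limit and not a number: the limit of > 60000 nM in this assay, at which 1 of the 3 values shown sits.

Whether any group on this aromatic carbon can move the number beyond the scatter remains open, as the only groups shown there are two halogens, and an amine, a carboxylic acid or a methoxy group would be a much larger change than one halogen for another. Also open, from the compounds shown here alone, is how the saturated ring carbon responds to groups other than ethoxy and phenyl, such as a longer chain or an amide, and whether any such group, alone or with a change on the aromatic carbon, brings the number clearly lower.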